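This account rests on a few compounds, and the source may have more. Where it says the series, first, only, none or still open, it means among the compounds named here.

Working notes on a dithiocarbonate series measured in an assay on HEK293 cells for inhibition of protein deacetylase HDAC6 (Homo sapiens); on this read-out higher numbers stand for weaker inhibition and lower numbers for stronger inhibition.

Of the compounds shown here, three have numbers so far. Compound 1 `CCSC(=S)SCC(=O)c1ccc(S(=O)(=O)Nc2ccc(OC)cc2)cc1` gives 245 nM in this assay, the lowest of the three. Compound 3 `CCSC(=S)SCC(=O)c1ccc(C(=O)NCCOc2ccccc2)cc1` gives 483 nM in this assay, a gap to compound 1 that stays within the scatter, so no order between compound 1 and compound 3 can be read from these two numbers. Compound 2 `CCSC(=S)SCC(=O)c1ccc(C)cc1` gives 1250 nM in this assay, a gap to compound 1 that lies beyond the scatter. No pair among these three differs in one place, so no single step is isolated.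

Compound 4 `CCSC(=S)SCC(=O)c1ccc(S(=O)(=O)Nc2ccc(Cl)cc2)cc1` has not been measured. It differs from compound 1 by chloro in place of methoxy on an aromatic carbon, with the chloro sitting on the aromatic carbon where the methoxy stood, para to a large group. Going by the values given here, nothing measured here speaks to this change; the only compounds with a sulfonamide on the core are compound 1 and compound 4. The step from compound 1 to compound 4 is expected to be small, within the scatter, with no direction favoured: a 1.1-fold higher number from compound 1 to compound 4 (0.03 log units; within the scatter). Compound 4 is therefore estimated at 260 nM in this assay, within a range of 100 nM to 650 nM.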

Compound 4, half-maximal inhibitory concentration: 340 nM
Beside the measured number, compound 4's estimate is 1.3-fold (0.12 log units) below it; the measured number falls inside the stated range.
By their numbers in this assay, from the lowest: compounds 1, 4 and 3 (each within the scatter of the next); then compound 2.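

Going by these compounds alone, this is the first step isolated at a single place: chloro in place of methoxy, on an aromatic carbon para to a large group, gives a 1.4-fold higher number from compound 1 to compound 4 (0.14 log units; within the scatter) in this assay. The exchange removes one hydrogen-bond acceptor and one heavy atom, yet no order between the two compounds can be read, so the methoxy is not shown to be needed for the number seen with compound 1. No measured information bears on why this step is so small.

Open, from the compounds shown here alone, is whether an amine, a carboxylic acid or a longer alkoxy chain at this place would stay as close to compound 1 as the chloro does, or move the number beyond the scatter. Also open is what the sulfonamide contributes, since no pair shown differs only there.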